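Swapping sulfonyl for thioether on the fluoro analogue

The source may report more compounds than this note shows. Statements on the series, on what has been measured and on what is new or still open speak of the compounds shown alone.

Compound 3 `CS(=O)(=O)c1ccc(F)cc1NCC1=NCCN1` sits second highest of the three numbers in an assay for binding affinity to Alpha-1D adrenergic receptor (Homo sapiens), read by radioligand binding (on this read-out higher numbers stand for weaker inhibition and lower numbers for stronger inhibition), where compound 3 gives 2630 nM. Its nearest neighbour, compound 1 `COc1ccc(S(C)(=O)=O)c(NCC2=NCCN2)c1`, gives 7590 nM, and the step from there, a 2.9-fold lower number from compound 1 to compound 3 (0.46 log units; beyond the scatter), is modest. Compound 2 `CSc1ccc(C)cc1NCC1=NCCN1`, which carries a methylsulfanyl group, gives 17.4 nM, far lower. Compound 4 `CSc1ccc(F)cc1NCC1=NCCN1` differs from compound 3 by methylsulfanyl in place of methylsulfonyl on an aromatic carbon. For the measured compounds named here, no measured step isolates this change, but the two values of compound 2 and compound 3 show that the methylsulfanyl-bearing compound lies far down the scale. For compound 4 a large drop is therefore expected, a 66-fold lower number from compound 3 to compound 4 (1.82 log units; beyond the scatter), and compound 4 is estimated at 40 nM, between 8 nM and 250 nM.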

Compound 4, inhibition constant: 6.17 nM
The estimate for compound 4 lay 6.5-fold (0.81 log units) above the measured number; the measured number lies below the stated range.
By their numbers in this assay, from the lowest: compound 4; then compound 2; then compound 3; then compound 1.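

On the aromatic carbon para to a fluoro group, methylsulfanyl in place of methylsulfonyl gives a large step (a 430-fold lower number from compound 3 to compound 4 (2.63 log units; beyond the scatter)), so this swap is now seen on its own with the rest of the molecule unchanged. Fluoro in place of methyl moves the number far less (a 2.8-fold lower number from compound 2 to compound 4 (0.45 log units; beyond the scatter)), which leaves the sulfur group as the larger of the two changes in these compounds. Nothing shown here gives a cause for the drop.

On these data alone, whether an amine or a longer chain such as ethylsulfanyl would hold this low number at the same carbon stays open. So does the size of the same swap with a methoxy group in place of the fluoro.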